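A few compounds are considered here, and "the series" means these few. Any claim that something is new, unique, unknown or untested is made for them only; others in the source may bear on it.

Of the compounds shown here, three sharing one core have been measured in a functional assay on KB cells (Homo sapiens) for cytotoxicity, read by MTT assay, with a stated time of 3 days; a lower number here means a stronger inhibitor, a higher number a weaker inhibitor. Compound 1 `N#Cc1c(O)nc(SCc2nc3ccccc3[nH]2)nc1-c1ccccc1`, with a hydroxy group on an aromatic carbon, gives 6.2 nM. Compound 2 `N#Cc1c(Cl)nc(SCc2nc3ccccc3[nH]2)nc1-c1ccccc1`, with chloro there, gives 3.7 nM, and compound 3 `N#Cc1c(NN)nc(SCc2nc3ccccc3[nH]2)nc1-c1ccccc1`, with aminoamino there, gives 2.55 nM. Compound 3 therefore stands level with compound 2 and apart from compound 1 by only a modest margin. The three swaps at this carbon give a 1.7-fold lower number from compound 1 to compound 2 (0.22 log units; within the scatter), a 1.5-fold lower number from compound 2 to compound 3 (0.16 log units; within the scatter) and a 2.4-fold lower number from compound 1 to compound 3 (0.39 log units; beyond the scatter).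

Compound 4 `N#Cc1c(Nc2ccccc2)nc(SCc2nc3ccccc3[nH]2)nc1-c1ccccc1` brings a new change: phenyl in place of amino on a nitrogen on an aromatic ring. In words, this is phenyl in place of amino on a nitrogen on an aromatic ring. Within the data shown here, none of the measured compounds carries a ring at this place, so these small steps are only an indirect guide. They still suggest little movement, with the number expected to drift slightly upward and stay within the scatter. The expected change is a 1.6-fold higher number from compound 3 to compound 4 (0.20 log units; within the scatter). The estimate for compound 4 is 4 nM, with an expected range of 1.2 nM to 13 nM.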

Compound 4, half-maximal inhibitory concentration: 2.9 nM
Compound 4: middle estimate off by 1.4-fold (0.14 log units), on the high side; the range from low to high includes it.
By their numbers in this assay, from the lowest: compounds 3, 4, 2 and 1 (each within the scatter of the next, the first and the last beyond it).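

In this assay, among these compounds, replacing aminoamino with anilino puts a six-membered aromatic ring on the nitrogen and gives a 1.1-fold higher number from compound 3 to compound 4 (0.06 log units; within the scatter), so this place tolerates a ring, which none of the earlier compounds carried here. Anilino also stands level with chloro, at a 1.3-fold lower number from compound 2 to compound 4 (0.11 log units; within the scatter), and stands apart from hydroxy by only a modest margin, at a 2.1-fold lower number from compound 1 to compound 4 (0.33 log units; beyond the scatter). Nothing measured here explains why adding the ring changes the number so little.

On these data alone, it remains open whether a morpholine or a carboxylic acid on this aromatic carbon would keep the number in the same range. As far as these compounds go, it is also open whether a methoxy group or a chloro on the new phenyl ring would shift it.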